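This account rests on a few compounds, and the source may have more. Where it says the series, first, only, none or still open, it means among the compounds named here.

The series shares one core, seen in compound 1 `NS(=O)(=O)c1ccc(N2N=C(c3ccc(OCc4ccccc4)cc3)CC2c2ccccc2)cc1`, compound 2 `Cc1cccc(C2CC(c3ccc(OCc4ccccc4)cc3)=NN2c2ccc(S(N)(=O)=O)cc2)c1` and compound 3 `NS(=O)(=O)c1ccc(N2N=C(c3ccc(OCc4ccccc4)cc3)CC2c2ccccc2Cl)cc1`. In an ADME assay on BHK-21 cells (Mesocricetus auratus) for cytotoxicity, read by MTT assay, with a stated time of 72 h (on this read-out higher numbers stand for lower toxicity in this test and lower numbers for higher toxicity in this test), compound 1 gives 80000 nM, compound 2 gives 8000 nM and compound 3 gives 12000 nM, which is the second highest of the three. Substitution on that phenyl lowered the number, a 10-fold lower number from compound 1 to compound 2 (1.00 log units; beyond the scatter) and a 6.7-fold lower number from compound 1 to compound 3 (0.82 log units; beyond the scatter), while the swap between the substituted phenyls, a 1.5-fold higher number from compound 2 to compound 3 (0.18 log units; within the scatter), stayed within the scatter. Compound 4 `NS(=O)(=O)c1ccc(N2N=C(c3ccc(OCc4ccccc4)cc3)CC2c2cccc(F)c2)cc1` carries the change (3-fluorophenyl in place of 2-chlorophenyl on a saturated ring carbon). For the measured compounds named here, only the step of a 1.5-fold higher number from compound 2 to compound 3 (0.18 log units; within the scatter) bears directly on it, so in this assay no step beyond the scatter is expected, a 1.2-fold lower number from compound 3 to compound 4 (0.08 log units; within the scatter). For compound 4 the estimate is 10000 nM, between 4000 nM and 30000 nM.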

Compound 4, half-maximal cytotoxic concentration: 9000 nM
Estimate against measurement, compound 4: 1.1-fold (0.05 log units) above; the measured number falls inside the stated range.
By their numbers in this assay, from the lowest: compounds 2, 4 and 3 (each within the scatter of the next); then compound 1.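

In this assay, the exchange of 2-chlorophenyl for 3-fluorophenyl on the saturated ring carbon (a 1.3-fold lower number from compound 3 to compound 4 (0.12 log units; within the scatter)) shows that this position tolerates a third substituted phenyl with little difference, and the comparison with the methyl compound agrees (a 1.1-fold higher number from compound 2 to compound 4 (0.05 log units; within the scatter)). Fluoro also separates from the unsubstituted phenyl (an 8.9-fold lower number from compound 1 to compound 4 (0.95 log units; beyond the scatter)), so all three substituted compounds stand apart from compound 1. Nothing measured here explains this grouping. The step from compound 3 to compound 4 changes both the halogen and its place on the phenyl, and the two effects cannot be separated. Going by these compounds, whether an amine or a carboxylic acid on this phenyl would stay with compound 2, compound 3 and compound 4 or lie nearer compound 1 remains open.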